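A trifluoromethoxy swap near the limit of the assay

The compounds below may be only part of what the source reports. "The series", "measured", "known", "first", "only" and "open" are said of these compounds alone.

Among the measured compounds shown here, in an ADME assay on Raji cells (Homo sapiens) for cytotoxicity, with a stated time of 72 h (a lower number here means that less compound is needed, a higher number that more compound is needed for the effect), compound 3 (`Cc1cc(NC(=O)Nc2ccc(C(F)(F)F)cc2)c2ccccc2n1`) gives 23000 nM as the only actual number among the measured compounds. Compound 1 (`Cc1cc(NC(=O)Nc2ccc(C(C)(C)C)cc2)c2ccccc2n1`) gives only the limit > 25000 nM and no exact number. Compound 2 (`Cc1cc(NC(=O)Nc2ccc(N(C)C)cc2)c2ccccc2n1`) likewise gives only the limit > 25000 nM and no exact number.

Compound 4 (`Cc1cc(NC(=O)Nc2ccc(OC(F)(F)F)cc2)c2ccccc2n1`) has not yet been measured. It keeps the rest of compound 3 but carries trifluoromethoxy in place of trifluoromethyl on an aromatic carbon. This group sits on a six-membered aromatic ring of carbon only, para to a large group.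

Two measured steps changed the group at this same place: an at least 1.0-fold lower number from compound 1 to compound 3 (0.03 log units; that floor lies within the scatter) and an at least 1.0-fold lower number from compound 2 to compound 3 (0.03 log units; that floor lies within the scatter) in the same assay. Neither shows a change larger than the ordinary variation between repeat measurements. A third, a step that the two limits leave unreadable from compound 1 to compound 2 for this pair, adds no size.

With so little to go on, no step beyond the scatter is expected in this assay in either direction. The estimate for this change is a 1.0-fold lower number from compound 3 to compound 4 (0.02 log units; within the scatter) as the expected step. Compound 4 is expected at 22000 nM in this assay. Its estimated range runs from 10000 nM to 45000 nM as the likely span, and the result could also arrive as a limit alone.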

Compound 4, half-maximal effective concentration: 10000 nM
For compound 4 the middle estimate is 2.2-fold (0.34 log units) above the measured one; the range from low to high includes it.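

In this assay, among the compounds shown here, this position now shows a step beyond the scatter for the first time: exchanging trifluoromethyl for trifluoromethoxy gives a 2.3-fold lower number from compound 3 to compound 4 (0.36 log units; beyond the scatter). The same group also stands clear of the two groups whose compounds gave only a limit, with an at least 2.5-fold lower number from compound 2 to compound 4 (0.39 log units; beyond the scatter) and an at least 2.5-fold lower number from compound 1 to compound 4 (0.39 log units; beyond the scatter); these two sizes are floors, not exact steps. The earlier steps shown here at this place could show no change beyond the scatter, and the new steps from tert-butyl and dimethylamino remain floors, because those compounds rest on a limit of the assay: the limit of > 25000 nM in this assay, at which 2 of the 4 values shown sit.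

From the compounds shown here alone, whether a nitrile, a carboxylic acid or a longer chain at this place would lower the number further, or raise it again, stays open, since four compounds show only how these particular groups compare. Also open, going by these compounds, is whether the step from trifluoromethyl to trifluoromethoxy would appear again on a different core, and how large the true gaps to compound 1 and compound 2 are.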